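The compounds below may be only part of what the source reports. "The series", "measured", "known", "first", "only" and "open" are said of these compounds alone.

In a functional assay on A549 cells (Homo sapiens) for cytotoxicity, read by XTT assay, with a stated time of 72 h (on this read-out higher numbers stand for weaker inhibition and lower numbers for stronger inhibition), compound 1 `CCCCCCCC/C=C\CCCCCCCCOc1cc(O)cc(O)c1C(C)=O` gives only a limit, > 100000 nM. Compound 2 `CC(=O)c1c(O)c(CC=C(C)C)c(O)c(CC=C(C)C)c1O` likewise gives only a limit in this assay, > 100000 nM. Among the compounds with values here, compound 2 therefore stands at the limit of > 100000 nM in this assay, at which 2 of the 2 values shown sit, so no number is known for it and no step between measured compounds can be drawn from these two results. Compound 3 `CC(=O)c1c(O)cc(O)c(CC=C(C)C)c1O` differs from compound 2 by a single change: hydrogen in place of 3-methylbut-2-en-1-yl on an aromatic carbon. With both measured compounds sitting at the limit, nothing measured shows what such a change does in this assay, and the expectation can only carry the limit forward. The expected step, a number no higher from compound 2 to compound 3 (the limit leaves the size open), is none beyond the usual scatter. For compound 3 the estimate in this assay is 100000 nM, with a range from 30000 nM to 300000 nM, and it is more likely than not that only a limit rather than a number is reported.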

Compound 3, half-maximal inhibitory concentration: 29000 nM
The estimate for compound 3 lay 3.4-fold (0.54 log units) above the measured number; the measured number lies below the stated range.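

Within the data shown here, putting hydrogen in place of the 3-methylbut-2-en-1-yl group on this aromatic carbon, ortho to two hydroxy groups, gives the only true number so far in this assay, and the change reads as an at least 3.4-fold lower number from compound 2 to compound 3 (0.53 log units; beyond the scatter). The earlier compounds shown here sat at the limit and showed no direction for any change, whereas this result shows that inhibition at this position grows stronger when the group leaves. How much stronger stays unknown because compound 2 gives only a limit: the limit of > 100000 nM in this assay, at which 2 of the 3 values shown sit.

The compounds shown leave open whether hydrogen alone allows this result, since a methyl group, an ethyl group or an amine on this carbon is not among them. They also leave open what the 3-methylbut-2-en-1-yl group that remains in compound 3 contributes in this assay.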